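Hydroxymethyl gives way to ethoxycarbonyl on the shared core

The compounds below may be only part of what the source reports. "The series", "measured", "known", "first", "only" and "open" are said of these compounds alone.

Measured in a functional assay on SW480 cells (Homo sapiens) for cytotoxicity, read by MTT assay, with a stated time of 48 h; a lower number here means a stronger inhibitor, a higher number a weaker inhibitor:
compound 1 `CCOC(=O)[C@@]1(C(=O)Nc2ccccc2Cl)C[C@@H]1c1cc(OC)c(OC)c(OC)c1`: 46700 nM
compound 2 `COc1cc([C@H]2C[C@]2(CO)C(=O)Nc2ccccc2Cl)cc(OC)c1OC`: 40200 nM

In this assay compound 2 gives 40200 nM. That places it level with compound 1 at 46700 nM, since the two values lie within the scatter of each other. The data hold no measured pair that differs in one place only, so the effect of a single change on this read-out has not been shown.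

Compound 3 `CCOC(=O)[C@]1(C(=O)Nc2ccccc2Cl)C[C@@H]1c1cc(OC)c(OC)c(OC)c1` departs from compound 2 at one place, a saturated ring carbon of a three-membered non-aromatic ring of carbon only, where ethoxycarbonyl stands in place of hydroxymethyl (ethoxycarbonyl in place of hydroxymethyl on a saturated ring carbon). No step beyond the scatter is expected in this assay, and the direction is left open. This expectation rests on the two measured values alone, which sit together, with compound 1 at 46700 nM and compound 2 at 40200 nM. The expected change is small, an estimated 1.1-fold higher number from compound 2 to compound 3 (0.05 log units; within the scatter). For compound 3 the expected value is 45000 nM, with an estimated range from 20000 nM to 100000 nM.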

Compound 3, half-maximal inhibitory concentration: > 100000 nM
Compound 3 gave a limit, no number (the forecaster's own chance of this, stated with the estimate: 15%); at least 2.2-fold (0.34 log units) between middle value and limit.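

Compound 3 reads in this assay as a limit of the assay and not as a number: the limit of > 100000 nM in this assay, at which 1 of the 3 values shown sits.

Within the data shown here, on a saturated ring carbon of the three-membered ring, ethoxycarbonyl in place of hydroxymethyl gives an at least 2.4-fold higher number from compound 2 to compound 3 (0.39 log units; beyond the scatter), the first step to be measured at a single place, and it lies beyond the scatter. The ethoxycarbonyl group alone does not fix the read-out, since compound 1 carries the same group and the other step, an at least 2.1-fold higher number from compound 1 to compound 3 (0.33 log units; beyond the scatter), also lies beyond the scatter, so this position is sensitive to the configuration as drawn as well as to the group it carries: the fact that compounds 1 and 3 differ only in the configuration as drawn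

The compounds shown leave open how far compound 3 lies past its limit, and with it the full size of both steps. They also leave open whether a hydroxymethyl compound would answer to the same change of configuration, and how a carboxylic acid or an aminomethyl group would read on this ring carbon.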